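Methyl on the Amine Nitrogen of Compound 3

The source may report more compounds than this note shows. Statements on the series, on what has been measured and on what is new or still open speak of the compounds shown alone.

Compound 1 `N=c1sc2cc(OC(F)(F)F)ccc2n1CCS(N)(=O)=O` and compound 2 `CNS(=O)(=O)CCn1c(=N)sc2cc(OC(F)(F)F)ccc21` differ by methyl in place of hydrogen on a sulfonamide nitrogen. In a functional assay on the whole organism with Rattus norvegicus as the target (on this read-out higher numbers stand for an effect only at larger amounts of compound and lower numbers for an effect already at smaller amounts), compound 1 gives 6 mg/kg, and compound 2 gives 4 mg/kg, a step of a 1.5-fold lower number from compound 1 to compound 2 (0.18 log units; within the scatter). Compound 3 `CNCCn1c(=N)sc2cc(OC(F)(F)F)ccc21` has a different core, differing from compound 1 by methylamino in place of sulfamoyl on a saturated chain carbon, two bonds along the chain from an aromatic nitrogen. In this assay compound 3 gives only a limit of the assay, > 10 mg/kg. Compound 4 `CN(C)CCn1c(=N)sc2cc(OC(F)(F)F)ccc21` differs from compound 3 by methyl in place of hydrogen on an amine nitrogen. This is the same kind of change as that from compound 1 to compound 2, though the methyl now enters on an amine nitrogen whose other neighbours are saturated chain carbon, saturated chain carbon, not on a sulfonamide nitrogen whose other neighbour is sulfonyl sulfur. That expectation rests on the step of a 1.5-fold lower number from compound 1 to compound 2 (0.18 log units; within the scatter). The expected step is a step that the limit leaves unreadable from compound 3 to compound 4. Compound 4 is estimated at 12 mg/kg in this assay.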

Compound 4, dose for half-maximal effect: 2.3 mg/kg
Estimate against measurement, compound 4: 5.2-fold (0.72 log units) above, outside the stated range (below it).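

On the amine nitrogen, the methyl gives a larger step (an at least 4.3-fold lower number from compound 3 to compound 4 (0.63 log units; beyond the scatter)) than on the sulfonamide nitrogen, so the change does not carry over at one size between these two cores: the same change on two cores in this assay, a 1.5-fold lower number (0.18 log units; within the scatter) from compound 1 to compound 2 and an at least 4.3-fold lower number (0.63 log units; beyond the scatter) from compound 3 to compound 4, at least 2.8-fold (0.46 log units) apart, beyond the scatter of two such steps. The size on the amine is only a floor, and two cores set no rule for others or show why the steps differ: the limit of > 10 mg/kg in this assay, at which 1 of the 4 values shown sits. Replacing the whole sulfonamide group gives two further steps (a 1.7-fold lower number from compound 2 to compound 4 (0.24 log units; within the scatter)) (a 2.6-fold lower number from compound 1 to compound 4 (0.42 log units; beyond the scatter)), the second beyond the usual scatter and the first within it.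

Still open, from the compounds shown here alone, is how the amine step would look with ethyl in place of methyl on the amine nitrogen. Going by these compounds, a longer chain to the amine is equally open.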